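From 3-chlorophenyl to thiophen-2-yl at the assay limit

This account rests on a few compounds, and the source may have more. Where it says the series, first, only, none or still open, it means among the compounds named here.

Compound 1 `COc1cccc(/C=C/C(=O)c2ccc(OC)c3c2OC(C)(C)C=C3)c1` gives the limit > 10000 nM
Compound 2 `COc1ccc(C(=O)/C=C/c2ccc(Cl)cc2)c2c1C=CC(C)(C)O2` gives the limit > 10000 nM
Compound 3 `COc1ccc(C(=O)/C=C/c2cccc(Cl)c2)c2c1C=CC(C)(C)O2` gives the limit > 10000 nM

In a functional assay on HT-29 cells (Homo sapiens) for antiproliferative activity, read by MTT assay, with a stated time of 24 h (a higher number here means a weaker inhibitor, a lower number a stronger inhibitor), compound 3 sits at a limit of > 10000 nM and has no numerical value. The whole series shares this position, namely the limit of > 10000 nM in this assay, at which 3 of the 3 values shown sit, and so the three cannot be ranked. Compound 4 `COc1ccc(C(=O)/C=C/c2cccs2)c2c1C=CC(C)(C)O2` carries thiophen-2-yl in place of 3-chlorophenyl on a double-bonded chain carbon bound to a double-bonded chain carbon. The change is thiophen-2-yl in place of 3-chlorophenyl on a double-bonded chain carbon bound to a double-bonded chain carbon and it has not yet been tested. The relevant measured results are a step that the two limits leave unreadable from compound 1 to compound 2 and a step that the two limits leave unreadable from compound 1 to compound 3 and a step that the two limits leave unreadable from compound 2 to compound 3 and none of them gives a size. Compound 4 is therefore expected to remain weak, with no firm direction expected. The expected step is a step that the limit leaves unreadable from compound 3 to compound 4 in this assay as an estimate only. For compound 4 the estimated value is 15000 nM with an expected range from 4000 nM to 60000 nM in this assay for now.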

Compound 4, half-maximal inhibitory concentration: > 10000 nM
Compound 4 gave a limit, no number (the forecaster's own chance of this, stated with the estimate: 75%); the middle value does not contradict the limit.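

In this assay, among these compounds, no step between compound 4 and compound 1, compound 2 or compound 3 can be read, because all four share one limit: the limit of > 10000 nM in this assay, at which 4 of the 4 values shown sit. The compounds shown leave open which change to the shared core, if any, would give a measurable value.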